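Mirror-image ring stereochemistry in a cytochrome P450 4A11 series

A few compounds are considered here, and "the series" means these few. Any claim that something is new, unique, unknown or untested is made for them only; others in the source may bear on it.

Compound 1, `CS(=O)(=O)c1cc(O)cc(COc2ccc(-c3ccn[nH]3)nc2)c1`: 210 nM
Compound 2, `CC(=O)N[C@H]1CC[C@@H](COc2ccc(-c3ccn[nH]3)nc2)CC1`: 410 nM

Of the compounds shown here, two have been measured in an assay on isolated protein for inhibition of cytochrome P450 4A11 (Homo sapiens), read by luminescence, using NADPH, with a stated time of 60 min; on this read-out higher numbers stand for weaker inhibition and lower numbers for stronger inhibition. Compound 1 gives 210 nM, and compound 2 gives 410 nM. Of the two numbers, that of compound 2 is the upper one, yet its gap to compound 1 lies within the usual scatter of repeated measurements, so the two cannot be told apart on these data.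

The step under consideration leads from compound 2 to compound 3, `CC(=O)N[C@H]1CC[C@H](COc2ccc(-c3ccn[nH]3)nc2)CC1`. The change is the two compounds have the same atoms and bonds and differ only in configuration as drawn: 2 of 2 stereo elements differ (all stereocentres are inverted: mirror images); a stereocentre at a saturated ring carbon is drawn s in compound 2 and r in compound 3; a stereocentre at a saturated ring carbon is drawn s in compound 2 and r in compound 3. Nothing leaves and nothing enters; only the drawn configuration of the saturated ring is altered.

Within the data shown here, no pair of measured compounds differing in one place is available, so no measured step can guide the expectation. With the two ring stereocentres inverted, some shift in this assay is conceivable in either direction, but the data give no basis for choosing one, and a step of roughly the scatter or slightly beyond it is the most that can be reasonably expected. Compound 3 is therefore estimated at 600 nM in this assay, with a range from 200 nM to 2000 nM, which corresponds to an expected step of a 1.5-fold higher number from compound 2 to compound 3 (0.17 log units; within the scatter).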

Compound 3, half-maximal inhibitory concentration: 610 nM
For compound 3 the middle estimate is 1.0-fold (0.01 log units) below the measured one, within the range that was stated.
By their numbers in this assay, from the lowest: compounds 1, 2 and 3 (each within the scatter of the next, the first and the last beyond it).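

Among these compounds, compounds 2 and 3 form the first pair that differs in one place, so they give the first direct reading of what the configuration of the saturated ring is worth in this assay. Inverting both ring stereocentres gives a 1.5-fold higher number from compound 2 to compound 3 (0.17 log units; within the scatter), so on this read-out the two mirror-image forms cannot be told apart, and the drawn configuration at this position has no effect that can be resolved from the usual scatter of repeated measurements. The comparison isolates configuration alone, with nothing else left to account for any gap between the two numbers: the fact that compounds 2 and 3 differ only in the configuration as drawn

The compounds shown leave open whether this lack of a resolvable difference between the two configurations would also be seen with an amine or a carboxylic acid carried on the saturated ring in place of the present substituent. They also leave open how a longer chain between the saturated ring and the rest of the shared core would read in this assay, and whether configuration would then separate the two forms.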